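Chloro for hydrogen on the aryl group of compound 2

This account rests on a few compounds, and the source may have more. Where it says the series, first, only, none or still open, it means among the compounds named here.

Measured so far:
compound 1 `CCOC(=O)c1nnc2n(c1=O)CCN2c1ccc(Cl)c(Cl)c1` gives > 100000 nM
compound 2 `NNC(=O)c1nnc2n(c1=O)CCN2c1ccccc1` gives > 100000 nM

Both numbers come from a functional assay on LS180 cells (Homo sapiens) for inhibition, read by spectrophotometry and BrdU incorporation, with a stated time of 72 h; a lower number here means a stronger inhibitor, a higher number a weaker inhibitor. The value of compound 1, > 100000 nM, is a limit of the assay and not a number. The value of compound 2, > 100000 nM, is likewise a limit and not a number. For the measured compounds named here, compound 2 therefore stands at the limit of > 100000 nM in this assay, at which 2 of the 2 values shown sit, and nothing separates it from compound 1 on this read-out; no step between measured compounds can be stated.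

The next compound, compound 3 `NNC(=O)c1nnc2n(c1=O)CCN2c1cccc(Cl)c1`, differs from compound 2 in one place: chloro in place of hydrogen on an aromatic carbon.

Going by the values given here, with no measured step to lean on, and with compound 2 at > 100000 nM, the expectation is no shift beyond the scatter, most likely a limit again. The expected step from compound 2 to compound 3 is a number no higher from compound 2 to compound 3 (the limit leaves the size open). Compound 3 is expected near 100000 nM, within 30000 nM to 300000 nM.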

Compound 3, half-maximal inhibitory concentration: > 100000 nM
Compound 3 ended at the assay's limit; the forecaster's own chance of this, stated with the estimate: 80%; the middle value lies on the limit itself.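

Compound 3 gives > 100000 nM, a limit and not a number. For the compounds shown here, compound 2 gives > 100000 nM, likewise a limit, so no step between these two compounds can be read. The compounds shown leave open whether phenyl to 3-chlorophenyl shifts inhibition at all, and which change would bring a value off the limit: the limit of > 100000 nM in this assay, at which 3 of the 3 values shown sit.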